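This account rests on a few compounds, and the source may have more. Where it says the series, first, only, none or still open, it means among the compounds named here.

Compounds measured in a functional assay on PC-3 cells (Homo sapiens) for cytotoxicity, read by MTT assay, with a stated time of 72 h; on this read-out higher numbers stand for weaker inhibition and lower numbers for stronger inhibition:

Compound 1 `COc1ccc2c(c1)[n+]([O-])nc(NCOCc1ccccc1)[n+]2[O-]`: 88500 nM
Compound 2 `[O-][n+]1nc(NCOCc2ccccc2)[n+]([O-])c2ccccc21`: 11900 nM

For the measured compounds named here, compound 2 stands lowest of the two numbers; the only step bearing on it is a 7.4-fold lower number from compound 1 to compound 2 (0.87 log units; beyond the scatter), a modest change at a ring position and beyond the scatter. Compound 3 `CCCCCCCOCNc1n[n+]([O-])c2ccccc2[n+]1[O-]` differs from compound 2 in one place: hexyl in place of phenyl on a saturated chain carbon bound to an oxygen on a saturated carbon. No measured step touches this part of the structure, since the one step shown concerns a substituent on the aromatic ring and not the side chain, so the data give no guide to the direction or size of the change. The account therefore expects a step in this assay of about a 1.0-fold higher number from compound 2 to compound 3 (0.00 log units; within the scatter), that is, none beyond the scatter. Compound 3 is estimated at 12000 nM in this assay, with a range from 4000 nM to 36000 nM.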

Compound 3, half-maximal inhibitory concentration: 390 nM
For compound 3 the middle estimate is 31-fold (1.49 log units) above the measured one; measured number below the stated range.
By their numbers in this assay, from the lowest: compound 3; then compound 2; then compound 1.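

In this assay this part of the side chain turns out to matter: hexyl in place of phenyl on a saturated chain carbon bound to an oxygen on a saturated carbon gives a 31-fold lower number from compound 2 to compound 3 (1.48 log units; beyond the scatter) and so a large move. For the compounds shown here, the earlier compounds showed only a change on the aromatic ring, so this is the first sign that the side chain also responds, and that a chain without a ring, with the same count of heavy atoms as phenyl, is accepted here. No measured property is at hand to account for this step.

The compounds shown leave open whether the number keeps falling with a longer chain such as decyl, and whether cyclohexyl reads more like hexyl or like phenyl. They also leave open how an amine on the chain would read, and whether methoxy on the aromatic carbon would raise the number with hexyl as it does with the phenyl side chain.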